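This account rests on a few compounds, and the source may have more. Where it says the series, first, only, none or still open, it means among the compounds named here.

Measured in a functional assay on L1210 cells (Mus musculus) for antiproliferative activity; a lower number here means a stronger inhibitor, a higher number a weaker inhibitor:
compound 1 `COc1cc(C(=O)c2sc(-c3ccc([N+](=O)[O-])cc3)cc2N)cc(OC)c1OC` gives 100 nM
compound 2 `COc1cc(C(=O)c2sc(-c3cccc([N+](=O)[O-])c3)cc2N)cc(OC)c1OC` gives 11 nM
compound 3 `COc1cccc(-c2cc(N)c(C(=O)c3cc(OC)c(OC)c(OC)c3)s2)c1` gives 22 nM

Compound 2 has the lowest number of the three; its gap to compound 3, a 2.0-fold higher number from compound 2 to compound 3 (0.30 log units; within the scatter), is within the scatter, so no order is drawn between those two, and only compound 1 stands apart, a 9.1-fold lower number from compound 1 to compound 2 (0.96 log units; beyond the scatter). Compound 4 `COc1cc(C(=O)c2sc(-c3cccs3)cc2N)cc(OC)c1OC` is not yet measured. The change: thiophen-2-yl in place of 3-nitrophenyl on an aromatic carbon. Among the compounds with values here, no measured step swaps the six-membered aryl group for a five-membered ring; the steps that bear on this position are a 9.1-fold lower number from compound 1 to compound 2 (0.96 log units; beyond the scatter) and a 4.5-fold lower number from compound 1 to compound 3 (0.66 log units; beyond the scatter), both modest, showing that this position moves the number modestly. A modest shift toward a higher number is therefore expected for compound 4, a 2.7-fold higher number from compound 2 to compound 4 (0.44 log units; beyond the scatter), with wide uncertainty. The estimate for compound 4 is 30 nM, in the range 8 nM to 120 nM.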

Compound 4, half-maximal inhibitory concentration: 9.8 nM
Beside the measured number, compound 4's estimate is 3.1-fold (0.49 log units) above it; the range from low to high includes it.
By their numbers in this assay, from the lowest: compounds 4, 2 and 3 (each within the scatter of the next, the first and the last beyond it); then compound 1.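

In this assay, a five-membered aromatic ring with a sulfur is accepted on this aromatic carbon next to the ring sulfur: thiophen-2-yl, with fewer heavy atoms and no nitro group, holds level with 3-nitrophenyl (a 1.1-fold lower number from compound 2 to compound 4 (0.05 log units; within the scatter)). The same group also compares favourably with 3-methoxyphenyl (a 2.2-fold lower number from compound 3 to compound 4 (0.35 log units; beyond the scatter)) and 4-nitrophenyl (a 10-fold lower number from compound 1 to compound 4 (1.01 log units; beyond the scatter)), so a six-membered aryl group is not required here. Nothing measured on hand bears on the reason for these steps.

Still open, as far as these compounds go, is whether furan-2-yl or thiophen-3-yl would sit at the same level. A phenyl ring carrying a carboxylic acid or a dimethylamino group is also untested in the compounds shown.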